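A few compounds are considered here, and "the series" means these few. Any claim that something is new, unique, unknown or untested is made for them only; others in the source may bear on it.

In a functional assay on DU-145 cells (Homo sapiens) for inhibition, read by sulforhodamine B assay, with a stated time of 48 h (on this read-out higher numbers stand for weaker inhibition of growth and lower numbers for stronger inhibition of growth), compound 1 (`COc1ccc2c(c1O)CCCC=C2c1cc(OC)c(OC)c(OC)c1`) gives 0.0032 nM, and compound 2 (`COc1ccc(C(=O)C2=CCCc3c2cc(OC)c(OC)c3OC)c(O)c1O`) gives 3400 nM. Among the compounds with values here, compound 1 has the lower of the two numbers so far, and the gap between the two lies beyond the scatter. Compound 3 (`COc1ccc2c(c1)CCCC=C2c1cc(OC)c(OC)c(OC)c1`) differs from compound 1 by hydrogen in place of hydroxy on an aromatic carbon. Within the data shown here, no measured pair isolates this change, so the size of the step remains a judgement. The expected step is a 6300-fold higher number from compound 1 to compound 3 (3.80 log units; beyond the scatter), a large rise in the number, meaning weaker inhibition of growth, well beyond the scatter. The estimate for compound 3 is 20 nM, with an expected range from 0.5 nM to 500 nM.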

Compound 3, concentration for 50% growth inhibition: 27 nM
Beside the measured number, compound 3's estimate is 1.4-fold (0.13 log units) below it, and the stated range covers the measured number.
By their numbers in this assay, from the lowest: compound 1; then compound 3; then compound 2.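

Within the data shown here, replacing the hydroxy ortho to a methoxy group and ortho to a fused ring with hydrogen gives, in this assay, an 8400-fold higher number from compound 1 to compound 3 (3.93 log units; beyond the scatter) and is the first single-place step. The hydroxy at this position therefore matters greatly to the low number of compound 1, although compound 3 still gives 27 nM without it. Nothing on hand explains the size of this step.

As far as these compounds go, whether an amine or fluorine at this position would preserve the low number remains open. So does whether an amino group could stand in for the hydroxy elsewhere on the shared core.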